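Bare cyclohexyl replaces the phenylcarbamoyl-bearing ring

The compounds below may be only part of what the source reports. "The series", "measured", "known", "first", "only" and "open" are said of these compounds alone.

Measured compounds:
compound 1, `NS(=O)(=O)NC[C@H]1CC[C@H](C(=O)/C(=N/O)Nc2ccc(F)c(Br)c2)CC1` — 198 nM
compound 2, `O=C(Nc1ccccc1)[C@H]1CC[C@H](C(=O)/C(=N/O)Nc2ccc(F)c(Br)c2)CC1` — 150 nM
compound 3, `O=C(/C(=N/O)Nc1ccc(F)c(Br)c1)C1CCN(S(=O)(=O)Nc2ccccc2)CC1` — 98 nM

In an assay for inhibition of Indoleamine 2,3-dioxygenase 1 (Homo sapiens), with a stated time of 1 h (on this read-out higher numbers stand for weaker inhibition and lower numbers for stronger inhibition), compound 2 stands second highest of the three numbers; compound 1 lies nearest and compound 3 furthest, both within the scatter. Compound 4, `O=C(/C(=N/O)Nc1ccc(F)c(Br)c1)C1CCCCC1`, differs from compound 2 by hydrogen in place of phenylcarbamoyl on a saturated ring carbon. Among the compounds with values here, the only measured step at this saturated ring carbon, a 1.3-fold lower number from compound 1 to compound 2 (0.12 log units; within the scatter), exchanged one large group for another and stayed within the scatter; no measured step removes the group altogether, so the bare ring is untested. Compound 4 is expected to give a somewhat higher number, the expected step being a 2.7-fold higher number from compound 2 to compound 4 (0.43 log units; beyond the scatter). For compound 4 the estimate in this assay is 400 nM, with a range from 150 nM to 1200 nM.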

Compound 4, half-maximal inhibitory concentration: 132 nM
For compound 4 the middle estimate is 3.0-fold (0.48 log units) above the measured one, and the stated range ends above it.
By their numbers in this assay, from the lowest: compounds 3, 4, 2 and 1 (each within the scatter of the next, the first and the last beyond it).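

In this assay the large group on the saturated ring carbon can go altogether: the steps of a 1.1-fold lower number from compound 2 to compound 4 (0.06 log units; within the scatter) and a 1.5-fold lower number from compound 1 to compound 4 (0.18 log units; within the scatter) both lie within the scatter. Neither phenylcarbamoyl nor (sulfamoylamino)methyl is shown to add to inhibition over hydrogen at this place, which the earlier exchange of one large group for another could not show. No measurement in hand accounts for this result.

Open, on these data alone, is whether a small group on this ring carbon, such as a hydroxyl, an amine or a carboxylic acid, would shift the number. As far as these compounds go, a longer chain ending in an amine at the same place also remains open.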